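From compound 3 to compound 4: one exchange on nitrogen

The compounds below may be only part of what the source reports. "The series", "measured", "known", "first", "only" and "open" are said of these compounds alone.

Values from a functional assay on RS4-11 cells (Homo sapiens) for inhibition, read by CCK-8 assay, with a stated time of 48 h (a lower number here means a stronger inhibitor, a higher number a weaker inhibitor), so far:
- compound 1 `O=C(NCCNS(=O)(=O)c1ccc(-c2ccccc2O[C@H]2CC[C@H](O)CC2)s1)Nc1cc(C(F)(F)F)cc(C(F)(F)F)c1` gives 10100 nM
- compound 2 `Cc1ccc(-c2ccsc2S(=O)(=O)NCCNC(=O)Nc2ccc([N+](=O)[O-])cc2)c(Oc2ccc(O)c(O)c2)c1` gives 7700 nM
- compound 3 `Cc1ccc(-c2ccsc2S(=O)(=O)NCCNC(=S)Nc2ccc([N+](=O)[O-])cc2)c(Oc2ccc(O)c(O)c2)c1` gives 5100 nM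

Compound 3, at 5100 nM in this assay, lies within the scatter of both other compounds. Compound 4 `Cc1ccc(-c2ccsc2S(=O)(=O)NCCNC(=O)Nc2cccc([N+](=O)[O-])c2)c(Oc2ccc(O)c(O)c2)c1` differs from compound 3 by a group of 12 heavy atoms (7 carbon, 2 nitrogen, 3 oxygen; one six-membered aromatic ring of carbon only) in place of a group of 12 heavy atoms (7 carbon, 2 nitrogen, 2 oxygen, 1 sulfur; one six-membered aromatic ring of carbon only), on an amine nitrogen, with (3-nitrophenyl)carbamoyl entering on an amine nitrogen. Within the data shown here, one measured step bears on this place: a 1.5-fold lower number from compound 2 to compound 3 (0.18 log units; within the scatter), which stays within the scatter. No step beyond the scatter is therefore expected in this assay, and no direction can be firmly claimed. The estimated step is a 1.4-fold higher number from compound 3 to compound 4 (0.14 log units; within the scatter) as a working expectation. For compound 4 the expected value is 7000 nM, with an estimated range from 3000 nM to 16000 nM when it is measured.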

Compound 4, half-maximal inhibitory concentration: 9100 nM
Compound 4: middle estimate off by 1.3-fold (0.11 log units), on the low side; measured number inside the range.
By their numbers in this assay, from the lowest: compounds 3, 2, 4 and 1 (each within the scatter of the next).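

In this assay, 3-nitrophenyl in place of 4-nitrophenyl on an amide-type nitrogen gives a 1.2-fold higher number from compound 2 to compound 4 (0.07 log units; within the scatter) and so shows that the site of the nitro group on this ring makes no difference beyond the scatter. The wider exchange on the amine nitrogen, with oxygen in place of sulfur as well as the shifted nitro group, gives a 1.8-fold higher number from compound 3 to compound 4 (0.25 log units; within the scatter) and also stays within the scatter. No measurement shown explains either step.

Going by these compounds, whether an amine or a carboxylic acid in place of the nitro group would shift the number beyond the scatter remains open.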